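The source may report more compounds than this note shows. Statements on the series, on what has been measured and on what is new or still open speak of the compounds shown alone.

Measured compounds:
compound 1 `COc1ccc(-c2cc(C(=O)Nc3ccc(Oc4ccnc5cc(OCCCN6CCCCC6)c(OC)cc45)c(F)c3)c3ccccc3n2)cc1` — 210 nM
compound 2 `COc1cc2c(Oc3ccc(NC(=O)c4cc(-c5cccc(Cl)c5)nc5ccccc45)cc3F)ccnc2cc1OCCCN1CCC(C)CC1` — 80 nM
compound 3 `COc1cc2c(Oc3ccc(NC(=O)c4cc(-c5ccccc5)nc5ccccc45)cc3F)ccnc2cc1OCCCN1CCC(C)CC1` — 160 nM

In a functional assay on SMMC-7721 cells (Homo sapiens) for cytotoxicity, read by MTT assay, with a stated time of 72 h (a lower number here means a stronger inhibitor, a higher number a weaker inhibitor), compound 3 gives 160 nM, the second highest of the three numbers. Its nearest neighbour is compound 1 with 210 nM, and the gap between them lies within the scatter. Among the measured compounds shown here, compound 2 gives 80 nM, and the single step that differs in one place, a 2.0-fold higher number from compound 2 to compound 3 (0.30 log units; within the scatter), also stays within the scatter.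

Compound 4 `COc1ccc(-c2cc(C(=O)Nc3ccc(Oc4ccnc5cc(OCCCN6CCC(C)CC6)c(OC)cc45)c(F)c3)c3ccccc3n2)cc1` has not yet been measured. It differs from compound 3 by methoxy in place of hydrogen on an aromatic carbon. For the measured compounds named here, no measured step among the three compounds bears directly on this change: the only step available concerns hydrogen in place of chloro on the same ring, and that step was small. Compound 1, which carries a 4-methoxyphenyl, and compound 3 show numbers within the scatter of each other, and compounds 1 and 2 differ in more than one place, so nothing isolates the methoxy group.

On this basis compound 4 is expected to stay close to compound 3, with a step of a 1.1-fold higher number from compound 3 to compound 4 (0.03 log units; within the scatter) that need not exceed the scatter. The estimate for compound 4 in this assay is 170 nM, within a range from 70 nM to 400 nM.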

Compound 4, half-maximal inhibitory concentration: 450 nM
For compound 4 the middle estimate is 2.6-fold (0.42 log units) below the measured one; measured number above the stated range.
By their numbers in this assay, from the lowest: compounds 2, 3 and 1 (each within the scatter of the next, the first and the last beyond it); then compound 4.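

In this assay, among the compounds shown here, the change from phenyl to 4-methoxyphenyl, on an aromatic carbon para to a large group, gives a 2.8-fold higher number from compound 3 to compound 4 (0.45 log units; beyond the scatter), the first single change on this ring to pass the scatter; hydrogen in place of chloro stayed within it, with a 2.0-fold higher number from compound 2 to compound 3 (0.30 log units; within the scatter). Replacing 3-chlorophenyl with 4-methoxyphenyl gives a larger step, a 5.6-fold higher number from compound 2 to compound 4 (0.75 log units; beyond the scatter), and with 4-methoxyphenyl in place, the methyl on the saturated ring also counts, with a 2.1-fold higher number from compound 1 to compound 4 (0.33 log units; beyond the scatter). No measurement at hand explains any of these steps.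

The compounds shown leave open whether the step belongs to the methoxy group itself or to its place on the ring, which a 3-methoxyphenyl or a 4-chlorophenyl would help to separate. They also leave open whether a hydroxy group, an amine or a longer chain such as ethoxy at the same place would give a similar step, and whether the methyl step would hold with a plain phenyl or a 3-chlorophenyl.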